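The compounds below may be only part of what the source reports. "The series", "measured", "known", "first", "only" and "open" are said of these compounds alone.

For the measured compounds named here, compound 1 `CC(C)(C)n1ncc(OCc2nnc(-c3ccc(Br)cc3)o2)c(Cl)c1=O` gives 3.21 in a physicochemical assay for lipophilicity (a higher number here means a more lipophilic compound, a lower number a more polar compound), the higher of the two numbers measured so far; compound 2 `CC(C)(C)n1ncc(OCc2nnc(-c3c(F)cccc3F)o2)c(Cl)c1=O` gives 2.75. Going by the values given here, the single measured step, a number 0.46 log units lower from compound 1 to compound 2 (beyond the scatter), alters the aryl group in a different way from the change now considered, so it offers only a loose guide to how far this read-out can move. Compound 3 `COc1ccc(-c2nnc(COc3cnn(C(C)(C)C)c(=O)c3Cl)o2)cc1` differs from compound 1 by methoxy in place of bromo on an aromatic carbon. Compound 3 is expected to read lower, by an estimated step of a number 0.76 log units lower from compound 1 to compound 3 (beyond the scatter). Compound 3 is therefore expected at 2.45, within a range from 2.05 to 2.85.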

Compound 3, partition coefficient: 3.52
Estimate against measurement, compound 3: 1.07 log units below; the whole stated range lies below it.
By their numbers in this assay, from the lowest: compound 2; then compound 1; then compound 3.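

At this position, methoxy in place of bromo moves the read-out in this assay upward, a number 0.31 log units higher from compound 1 to compound 3 (beyond the scatter), although the entering group adds a hydrogen-bond acceptor. The other new step, a number 0.77 log units higher from compound 2 to compound 3 (beyond the scatter), places compound 3 at the top of the three compounds and gives the widest gap among them. Nothing available accounts for the direction of the methoxy step. As far as these compounds go, whether an amine or ethoxy at this position would read above or below compound 3 remains open, as does whether methoxy would give the same rise on another carbon of the ring.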